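The compounds below may be only part of what the source reports. "The series", "measured", "known", "first", "only" and "open" are said of these compounds alone.

Compound 1 `CC1=NC(C)=C([N+](=O)[O-])C(c2cccc(C)n2)/C1=C(/O)OC(C)C` and compound 2 `CC1=NC(C)=C([N+](=O)[O-])C(c2ncccc2C)/C1=C(/O)OC(C)C` share one core and differ only in 3-methylpyridin-2-yl in place of 6-methylpyridin-2-yl on a saturated ring carbon. In a functional assay (muscle tissue) with Cavia porcellus as the target (on this read-out higher numbers stand for weaker inhibition and lower numbers for stronger inhibition), compound 1 gives 25100 nM, while compound 2 gives 2820 nM, so the change brought an 8.9-fold lower number from compound 1 to compound 2 (0.95 log units; beyond the scatter). Compound 3 `CC1=NC(C)=C([N+](=O)[O-])C(c2cccc(C)n2)/C1=C(/O)OCCc1ccccc1` keeps the core of compound 1 and differs from it by phenethyl in place of isopropyl on an oxygen on an unsaturated carbon; in this assay compound 3 gives 9980 nM, which is a 2.5-fold lower number from compound 1 to compound 3 (0.40 log units; beyond the scatter). Among these three compounds, compound 3 stands second highest in number, with compound 1 the nearest and compound 2 the furthest from it.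

Compound 4 `CC1=NC(C)=C([N+](=O)[O-])C(c2ncccc2C)/C1=C(/O)OCCc1ccccc1` has not yet been measured. It differs from compound 3 by 3-methylpyridin-2-yl in place of 6-methylpyridin-2-yl on a saturated ring carbon, and this is the same change that separates compound 1 from compound 2, made at a place described in the same words. Going by the values given here, the only measured example of this change is the step from compound 1 to compound 2, and with just one example there is no way to tell whether the other group on the oxygen alters its size. The step from compound 3 to compound 4 in this assay is therefore expected to be of similar size, roughly a 7.7-fold lower number from compound 3 to compound 4 (0.89 log units; beyond the scatter), because an 8.9-fold lower number from compound 1 to compound 2 (0.95 log units; beyond the scatter) was seen on the same core. On that basis compound 4 is estimated to give about 1300 nM in this assay, with a likely range from 500 nM to 3500 nM.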

Compound 4, half-maximal inhibitory concentration: 5430 nM
Estimate against measurement, compound 4: 4.2-fold (0.62 log units) below; measured number outside the range, above it.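

With phenethyl on the oxygen, the swap to 3-methylpyridin-2-yl gives a 1.8-fold lower number from compound 3 to compound 4 (0.26 log units; within the scatter), and in this assay this does not match the step seen with isopropyl: the same change on two cores in this assay, an 8.9-fold lower number (0.95 log units; beyond the scatter) from compound 1 to compound 2 and a 1.8-fold lower number (0.26 log units; within the scatter) from compound 3 to compound 4, 4.8-fold (0.69 log units) apart, beyond the scatter of two such steps. Phenethyl in place of isopropyl gives a 1.9-fold higher number from compound 2 to compound 4 (0.28 log units; within the scatter) when 3-methylpyridin-2-yl is present, so the size of that change also depends on the other group in the molecule: the same change on two cores in this assay, a 2.5-fold lower number (0.40 log units; beyond the scatter) from compound 1 to compound 3 and a 1.9-fold higher number (0.28 log units; within the scatter) from compound 2 to compound 4, 4.8-fold (0.69 log units) apart, beyond the scatter of two such steps. In this set the two changes do not simply add up, so a step measured on one core is a poor guide to its size on the other, but both gaps come from the same four compounds, making this one finding seen from two sides, and it does not show why the steps differ.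

The compounds shown leave open whether a methyl group or a longer chain such as phenylpropyl on the oxygen would follow the isopropyl or the phenethyl pattern. They also leave open how a plain phenyl group would behave in place of either methylpyridinyl group.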